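Enantiomer of the phenylacetamide benzamide in the enzyme assay

The source may hold more compounds than are shown below. What is called first, only, known or untested is meant among the compounds shown, and "the series" means these compounds.

Compound 1 `CC(C)[C@@H](C(=O)Nc1ccc(C(=O)Nc2ccccc2N)cc1)c1ccccc1` is the reference point of this small set. In an assay on isolated protein for inhibition of histone deacetylase 8 (Homo sapiens), read by fluorescence, tested at 1 uM (on this read-out lower numbers stand for less inhibition and higher numbers for more inhibition at the one concentration tested (going by the name of the read-out)), compound 1 gives 38%, the highest number of the three measured compounds. Compound 2 `CC(C)(C(=O)Nc1ccc(C(=O)Nc2ccccc2N)cc1)c1ccccc1` gives 0% in this assay, and compound 3 `CC(C)[C@@H](C(=O)Nc1ccc(C(=O)Nc2ccc(C(F)(F)F)cc2N)cc1)c1ccccc1` gives 0%. Going by the values given here, the one step that is catalogued as a single change, from compound 1 to compound 3, is a number 38 percentage points lower from compound 1 to compound 3 (beyond the scatter), so the trifluoromethyl on the aromatic carbon removes the inhibition entirely. The pair of compound 1 and compound 2 is not treated as a single-point step here; their two values simply show that the compound lacking the stereocentre sits at the bottom of the set.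

Compound 4 `CC(C)[C@H](C(=O)Nc1ccc(C(=O)Nc2ccccc2N)cc1)c1ccccc1` is the next compound to be tested in this assay. The change from compound 1 to compound 4 is the two compounds have the same atoms and bonds and differ only in configuration as drawn: 1 of 1 stereo elements differ; a stereocentre at a saturated chain carbon is drawn R in compound 1 and S in compound 4. Among the compounds with values here, no measured step in this set touches the configuration of that stereocentre, so none of the recorded steps bears directly on this change, and the measured steps only show how easily the inhibition of compound 1 is lost. An inversion at the only stereocentre is expected to lower inhibition or leave it roughly unchanged rather than raise it; the expected step from compound 1 to compound 4 is a number 23 percentage points lower from compound 1 to compound 4 (beyond the scatter). In this assay compound 4 is therefore estimated to give 15%, with a range from 0% to 40%.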

Compound 4, a percentage reported as inhibition, at one concentration (the size of the read-out at that concentration, not a potency): 7%
For compound 4 the middle estimate is 8 percentage points above the measured one, within the range that was stated.
By their numbers in this assay, from the lowest: compounds 2, 3 and 4 (each within the scatter of the next); then compound 1.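

In this assay, going by these compounds alone, inverting the stereocentre at the saturated chain carbon gives a number 31 percentage points lower from compound 1 to compound 4 (beyond the scatter), the only recorded step at this position, and it is a large one. This step can be assigned to the configuration alone, because nothing else separates the two compounds: the fact that compounds 1 and 4 differ only in the configuration as drawn. Within the data shown here, the earlier trifluoromethyl step concerned an aromatic carbon, so the series now has a second, separate place where a single change costs a large part of the reading, and at this position the inhibition seen for the shared core goes with the configuration drawn R in compound 1 rather than the one drawn S in compound 4.

On these data alone, it remains open whether the same dependence on configuration holds when a longer chain or an amine is carried on the stereocentre, or when the trifluoromethyl group of compound 3 is paired with the configuration of compound 4. Each reading also comes from one concentration only, so the size of the difference between the two configurations as a potency remains undefined.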